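The compounds below may be only part of what the source reports. "The series", "measured", "known", "first", "only" and "open" are said of these compounds alone.

- Compound 1 `COc1cc(/C=C/C(=O)O[C@H]2CC[C@@H](N(C)CCCOC(=O)c3cc(OC)c(OC)c(OC)c3)CC2)cc(OC)c1OC`: >= 4 h
- Compound 2 `COc1cc(/C=C/C(=O)OCCCN(C)[C@H]2CC[C@@H](OC(=O)c3cc(OC)c(OC)c(OC)c3)CC2)cc(OC)c1OC`: 2 h

Within the data shown here, in an ADME assay on a cell-free system (plasma, Homo sapiens) for metabolic stability, read by LC-MS (on this read-out lower numbers stand for a shorter-lived compound and higher numbers for a longer-lived compound), compound 2 gives 2 h, the only exact number so far. Compound 1 reads >= 4 h, which is a limit of the assay and not a number.

Compound 3 `COc1cc(/C=C/C(=O)OCCCN(C)[C@H]2CC[C@H](OC(=O)c3cc(OC)c(OC)c(OC)c3)CC2)cc(OC)c1OC` has the same atoms and bonds as compound 2 and differs only in configuration as drawn: the two compounds have the same atoms and bonds and differ only in configuration as drawn: 2 of 3 stereo elements differ; a stereocentre at a saturated ring carbon is drawn s in compound 2 and r in compound 3; a stereocentre at a saturated ring carbon is drawn s in compound 2 and r in compound 3. Among the measured compounds shown here, no measured pair shows what such a change does. A step beyond the usual scatter is not expected in this assay, in either direction, and the estimate starts from compound 2 at 2 h. The expected change is a 1.3-fold higher number from compound 2 to compound 3 (0.10 log units; within the scatter). The estimate for compound 3 is 2.5 h, with an expected range of 1.2 h to 5 h.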

Compound 3, half-life: <= 2 h
Compound 3 ended at the assay's limit; the forecaster's own chance of this, stated with the estimate: 20%; middle value at least 1.2-fold (0.09 log units) from the limit.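

In this assay, the change in configuration at the two saturated ring carbons gives a number no higher from compound 2 to compound 3 (the limit leaves the size open). From the compounds shown here alone, the reading for compound 3 is a limit of the assay and not a number, so the size of this step stays unknown. It is the first view of configuration at these ring carbons, and nothing else varies in this pair: the fact that compounds 2 and 3 differ only in the configuration as drawn

Going by these compounds, how far compound 3 really lies from compound 2 remains open. So does whether an amide in place of an ester, or a longer chain, would read differently in either configuration.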